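From 3-carboxypyrrolidin-1-yl to 3-carboxyazetidin-1-yl on a shared core

The source may report more compounds than this note shows. Statements on the series, on what has been measured and on what is new or still open speak of the compounds shown alone.

In a functional assay on HepG2 cells (Homo sapiens) for antiproliferative activity, read by CCK-8 assay, with a stated time of 48 h (a lower number here means a stronger inhibitor, a higher number a weaker inhibitor), compound 1 `COc1ccc(/C=C\c2cc(OC)c(OC)c(OC)c2)cc1OCc1ccc(C=O)cc1` gives 800 nM, while compound 2 `COc1ccc(/C=C\c2cc(OC)c(OC)c(OC)c2)cc1OCc1ccc(CN2CC[C@H](C(=O)O)C2)cc1` gives 6400 nM, the higher of the two numbers and so the weaker inhibitor of the pair. Compound 3 `COc1ccc(/C=C\c2cc(OC)c(OC)c(OC)c2)cc1OCc1ccc(CN2CC(C(=O)O)C2)cc1` keeps the core of compound 2 and alters one group: 3-carboxyazetidin-1-yl in place of 3-carboxypyrrolidin-1-yl on a saturated chain carbon bound to an aromatic carbon. Going by the values given here, only one measured step bears on this change. That step, an 8.0-fold higher number from compound 1 to compound 2 (0.90 log units; beyond the scatter), replaced a formyl group outright and is modest in size. The new change is narrower, since a five-membered non-aromatic ring gives way to a four-membered one. Among the compounds with values here, no measured pair shows what this swap alone does, so no shift beyond the scatter is expected in this assay. The expected change is small: a 1.1-fold lower number from compound 2 to compound 3 (0.03 log units; within the scatter). The estimated value for compound 3 is 6000 nM, with an expected range of 2500 nM to 15000 nM.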

Compound 3, half-maximal inhibitory concentration: > 10000 nM
Compound 3 was reported as a limit; the forecaster's own chance of this, stated with the estimate: 5%; at least 1.6-fold (0.22 log units) between middle value and limit.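

Compound 3 is reported in this assay only as a limit, not as an exact number: the limit of > 10000 nM in this assay, at which 1 of the 3 values shown sits. Read against that limit, the ring swap gives an at least 1.5-fold higher number from compound 2 to compound 3 (0.19 log units; that floor lies within the scatter), so going from the five-membered to the four-membered ring brought no gain in potency, yet this floor cannot tell the two ring sizes apart. Set against the formyl group, the new side chain gives an at least 12-fold higher number from compound 1 to compound 3 (1.09 log units; beyond the scatter), and with the earlier 8.0-fold higher number from compound 1 to compound 2 (0.90 log units; beyond the scatter) this shows that both carboxylic acid rings at this place give weaker inhibitors than the formyl compound.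

On these data alone, how far past the limit compound 3 really lies remains unknown, so the true size of the ring swap stays open. Also open, as far as these compounds go, is whether a six-membered piperidine ring bearing the same carboxylic acid, or a simple amine without the acid, would bring the number back towards that of compound 1.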